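A few compounds are considered here, and "the series" means these few. Any claim that something is new, unique, unknown or untested is made for them only; others in the source may bear on it.

Going by the values given here, compound 2 `N#CC1=C(N)Oc2c(N)cc3nc4ccccc4nc3c2C12C(=O)N(Cc1cnnn1-c1cc(Cl)ccc1Cl)c1ccccc12` is the only member of the series with a number in a functional assay on A549 cells (Homo sapiens) for antiproliferative activity, read by MTT assay, with a stated time of 48 h; a higher number here means a weaker inhibitor, a lower number a stronger inhibitor; in this assay compound 2 gives 10900 nM. Compound 1 `CCOc1ccccc1-n1nncc1CN1C(=O)C2(C(C#N)=C(N)Oc3c(N)cc4nc5ccccc5nc4c32)c2ccccc21` reaches only a limit in this assay, where compound 1 gives > 50000 nM. Among the compounds with values here, the one measured step, an at least 4.5-fold lower number from compound 1 to compound 2 (0.66 log units; beyond the scatter), is the sole guide to the aryl group on the ring nitrogen, and its size is bounded by the limit of > 50000 nM in this assay, at which 1 of the 2 values shown sits, so only a floor for that gain is known. Compound 3 `Cc1cc(C)c(-n2nncc2CN2C(=O)C3(C(C#N)=C(N)Oc4c(N)cc5nc6ccccc6nc5c43)c3ccccc32)c(C)c1` carries 2,4,6-trimethylphenyl in place of 2,5-dichlorophenyl on an aromatic nitrogen. Within the data shown here, no measured step compares two halogen-free aryl groups, and the lone step ran from an ethoxy-bearing ring to a chlorine-bearing one; a move to methyl groups has no direct precedent. The expectation is a small weakening, a 1.5-fold higher number from compound 2 to compound 3 (0.17 log units; within the scatter), within or near the scatter. A return of only a limit for compound 3 is also possible. Compound 3 is estimated at 16000 nM, with a range from 5000 nM to 50000 nM.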

Compound 3, half-maximal inhibitory concentration: 12700 nM
Estimate against measurement, compound 3: 1.3-fold (0.10 log units) above; the measured number falls inside the stated range.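

In this assay there is a 1.2-fold higher number from compound 2 to compound 3 (0.07 log units; within the scatter), so 2,4,6-trimethylphenyl and 2,5-dichlorophenyl on the aromatic nitrogen cannot be told apart, and chlorine on this aryl ring is not needed for a measurable number. There is also an at least 3.9-fold lower number from compound 1 to compound 3 (0.59 log units; beyond the scatter), which places a second, halogen-free aryl group on the same side of compound 1 as compound 2, so the earlier gain no longer rests on a single aryl group. The size of that gain remains a floor, as the value of compound 1 is a limit: the limit of > 50000 nM in this assay, at which 1 of the 3 values shown sits.

Open, from the compounds shown here alone, is how a plain phenyl or a methoxyphenyl would read here, which would test whether the ethoxy group sets compound 1 apart. Also open, going by these compounds, is whether an amine or a carboxylic acid on this aryl ring would move the number beyond the scatter.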